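Swapping the methoxy of compound 3 for trifluoromethyl

The source may report more compounds than this note shows. Statements on the series, on what has been measured and on what is new or still open speak of the compounds shown alone.

Compound 1 `COc1ccc(S(C)(=O)=O)c(NCC2=NCCN2)c1`: 14.1 nM
Compound 2 `CSc1ccc(C)cc1NCC1=NCCN1`: 0.11 nM
Compound 3 `COc1ccc(SC)c(NCC2=NCCN2)c1`: 1.59 nM

In a functional assay for agonist activity at Alpha-1A adrenergic receptor (Homo sapiens) (a higher number here means that more compound is needed for the effect, a lower number that less compound is needed), compound 3 sits between the other two: compound 1 gives a higher number, an 8.9-fold lower number from compound 1 to compound 3 (0.95 log units; beyond the scatter), while compound 2 gives a lower one, a 14-fold higher number from compound 2 to compound 3 (1.16 log units; beyond the scatter). Compound 4 `CSc1ccc(C(F)(F)F)cc1NCC1=NCCN1` differs from compound 3 in one place: trifluoromethyl in place of methoxy on an aromatic carbon, para to a methylsulfanyl group. For the measured compounds named here, no measured step replaces methoxy with trifluoromethyl; the only step touching this position, a 14-fold higher number from compound 2 to compound 3 (1.16 log units; beyond the scatter), shows that the group here can move the number a lot. With no direct guide, compound 4 is expected to land near compound 3, with a wide spread: a 1.3-fold lower number from compound 3 to compound 4 (0.12 log units; within the scatter). The estimate for compound 4 is 1.2 nM, between 0.15 nM and 10 nM.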

Compound 4, half-maximal effective concentration: 10.5 nM
For compound 4 the middle estimate is 8.8-fold (0.94 log units) below the measured one; measured number outside the range, above it.
By their numbers in this assay, from the lowest: compound 2; then compound 3; then compounds 4 and 1 (each within the scatter of the next).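

At this position, para to a methylsulfanyl group, trifluoromethyl needs more compound than either earlier group: in this assay there is a 6.6-fold higher number from compound 3 to compound 4 (0.82 log units; beyond the scatter), and a 95-fold higher number from compound 2 to compound 4 (1.98 log units; beyond the scatter). The earlier compounds shown here compared only methyl and methoxy here, whereas the three groups now form an order, with methyl needing the least compound, then methoxy, then trifluoromethyl. Nothing available here explains this order. Where a chlorine atom or an amine at this position would fall in that order remains open.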